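The source may hold more compounds than are shown below. What is called first, only, known or untested is meant among the compounds shown, and "the series" means these compounds.

In an ADME assay on HEK-293T cells (Homo sapiens) for cytotoxicity, read by luminescence and CellTiter-Glo, with a stated time of 24 h (a higher number here means that more compound is tolerated, a lower number that less compound is tolerated), compound 1, `CCCNC(=O)C1CCN(C(=O)c2cc3sc(-c4ccccc4)nc3n2Cc2ccc(OC)cc2)CC1`, gives 22900 nM. Compound 2, `CCCNC(=O)C1CCN(C(=O)c2cc3cc(Br)sc3n2Cc2ccc(OC)cc2)CC1`, reaches only a limit of the assay in this assay, > 100000 nM; that value sits at the limit of > 100000 nM in this assay, at which 1 of the 2 values shown sits. Compound 3, `CCCNC(=O)C1CCN(C(=O)c2cc3ccsc3n2Cc2ccc(OC)cc2)CC1`, differs from compound 2 by one change: hydrogen in place of bromo on an aromatic carbon. For the measured compounds named here, no measured pair shows how this change acts, so the step of a number no higher from compound 2 to compound 3 (the limit leaves the size open) is expected to be none beyond the usual scatter, with compound 2 already at the limit. For compound 3 a value of about 100000 nM is estimated, expected to fall between 40000 nM and 200000 nM.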

Compound 3, half-maximal cytotoxic concentration: 23400 nM
Beside the measured number, compound 3's estimate is 4.3-fold (0.63 log units) above it; the whole stated range lies above it.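

Swapping bromo for hydrogen on the aromatic carbon next to the ring sulfur gives an at least 4.2-fold lower number from compound 2 to compound 3 (0.63 log units; beyond the scatter) in this assay. For the compounds shown here, this is the first sign that this position affects how much compound the cells tolerate, with the bromo compound the better tolerated of the two. Going by these compounds, the true size of the step stays open because it starts from a limit: the limit of > 100000 nM in this assay, at which 1 of the 3 values shown sits.

The compounds shown leave open whether this belongs to bromo alone or to any group at this place; chloro, methyl or an amine there could separate the two. They also leave open whether the same change acts alike on another core.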